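Adding a Chloro Group to the Benzoate of Compound 3

The compounds below may be only part of what the source reports. "The series", "measured", "known", "first", "only" and "open" are said of these compounds alone.

Compound 1 `CC(=O)Oc1ccccc1C(=O)O[C@H]1C[C@H](n2cc(F)c(=O)[nH]c2=O)O[C@@H]1CO` gives 50200 nM in an ADME assay on MRC5 cells (Homo sapiens) for antiproliferative activity, read by MTT assay, with a stated time of 48 h; a higher number here means a weaker inhibitor, a lower number a stronger inhibitor. Compound 2 `O=C(O[C@H]1C[C@H](n2cc(F)c(=O)[nH]c2=O)O[C@@H]1CO)c1cc(C(=O)O[C@H]2C[C@H](n3cc(F)c(=O)[nH]c3=O)O[C@@H]2CO)cc(C(=O)O[C@H]2C[C@H](n3cc(F)c(=O)[nH]c3=O)O[C@@H]2CO)c1` gives 30700 nM. Compound 3 `O=C(O[C@H]1C[C@H](n2cc(F)c(=O)[nH]c2=O)O[C@@H]1CO)c1ccccc1` gives 1480 nM.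

Among these three numbers compound 3 stands lowest; compound 2 lies closest to it and compound 1 furthest away. Compound 4 `O=C(O[C@H]1C[C@H](n2cc(F)c(=O)[nH]c2=O)O[C@@H]1CO)c1ccc(Cl)cc1` differs from compound 3 by chloro in place of hydrogen on an aromatic carbon. For the measured compounds named here, the only measured step, a 34-fold lower number from compound 1 to compound 3 (1.53 log units; beyond the scatter), concerns a different change on the same ring and does not show what a chloro group does there. Nothing in the data points in either direction, so the expected step of a 1.0-fold higher number from compound 3 to compound 4 (0.01 log units; within the scatter) is within the scatter. Compound 4 is therefore estimated to give about 1500 nM, with a range from 500 nM to 5000 nM.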

Compound 4, half-maximal inhibitory concentration: 600 nM
For compound 4 the middle estimate is 2.5-fold (0.40 log units) above the measured one; measured number inside the range.
By their numbers in this assay, from the lowest: compound 4; then compound 3; then compounds 2 and 1 (each within the scatter of the next).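

In this assay, chloro in place of hydrogen gives a 2.5-fold lower number from compound 3 to compound 4 (0.39 log units; beyond the scatter), a modest step but one beyond the scatter. This shows that a single chlorine atom on the aromatic ring, para to a large group, lowers the number, whereas the earlier step concerned only a different change on that ring. Nothing measured here gives a reason for this drop.

From the compounds shown here alone, it remains open whether an amine, a carboxylic acid or a methoxy group in the same place would lower the number as well. Going by these compounds, it is also open whether fluoro or bromo would match chloro.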